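Replacing a pyrrolidinyl-ethylamino arm with a methylpiperidine ring

The compounds below may be only part of what the source reports. "The series", "measured", "known", "first", "only" and "open" are said of these compounds alone.

Measured compounds:
compound 1 `CC(C)Sc1nnc(-c2c(CNCCN3CCCC3)c3cc(F)ccc3n2C)n1-c1ccccc1` with 4.99
compound 2 `CC(C)Sc1nnc(-c2c(CNc3cnccn3)c3ccccc3n2C)n1-c1ccccc1` with 4.22

In a physicochemical assay for lipophilicity (a lower number here means a more polar compound, a higher number a more lipophilic compound), compound 1 gives 4.99. It stands highest of the two numbers shown, and its nearest neighbour is compound 2, whose value in this assay is 4.22, a gap that lies beyond the scatter of the method. The two compounds differ in more than one place, so their values are simply two points and nothing more is drawn from them together.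

Compound 3 `CC1CCCN(Cc2c(-c3nnc(SC(C)C)n3-c3ccccc3)n(C)c3ccc(F)cc23)C1` has not been measured in this assay. It arises from compound 1 by a single change: 3-methylpiperidin-1-yl in place of (2-(pyrrolidin-1-yl)ethyl)amino on a saturated chain carbon bound to an aromatic carbon. The group that enters carries one heavy atom fewer than the group that leaves, and it brings no hydrogen-bond donor where the leaving group had one.

Among the measured compounds shown here, no measured pair shows this exact change, so the expected size of the step rests on the counted difference alone. The expectation is that compound 3 will sit somewhat higher than compound 1, with a step of a number 0.51 log units higher from compound 1 to compound 3 (beyond the scatter) in this assay, clearly beyond the scatter but not a large one. Compound 3 is therefore estimated at 5.5, within a range from 4.9 to 6.1.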

Compound 3, partition coefficient: 6.18
Beside the measured number, compound 3's estimate is 0.68 log units below it; the whole stated range lies below it.
By their numbers in this assay, from the lowest: compound 2; then compound 1; then compound 3.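

On a saturated chain carbon bound to an aromatic carbon, 3-methylpiperidin-1-yl in place of (2-(pyrrolidin-1-yl)ethyl)amino gives, in this assay, a step of a number 1.19 log units higher from compound 1 to compound 3 (beyond the scatter), the first single-place comparison available at this position. The read-out therefore responds strongly to this change, although the two groups are close in size by count, with 7 heavy atoms entering against 8 leaving; the entering group also has 0 hydrogen-bond donors against 1 and 1 hydrogen-bond acceptor against 2. No measurement at hand bears on why the step is this large.

This one pair alters the ring size, the nitrogen count, the hydrogen-bond donor and the chain together, so the compounds shown leave open which of these differences carries the step. They also leave open where a piperidine ring without the methyl group, a morpholine ring, or the (2-(pyrrolidin-1-yl)ethyl)amino chain with a methyl group on its amine nitrogen would fall relative to compound 1 and compound 3.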